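Swapping a Piperazine for Bromine on a Urea Tail

The source may report more compounds than this note shows. Statements on the series, on what has been measured and on what is new or still open speak of the compounds shown alone.

Compound 1: `CNC(=O)c1cc(Oc2ccc3nc(NC(=O)Nc4ccc(N5CCN(C)CC5)cc4)sc3c2)ccn1` — 24.6%
Compound 2: `CNC(=O)c1cc(Oc2ccc3nc(NC(=O)Nc4ccc(C5CCN(C(C)C)CC5)cc4)sc3c2)ccn1` — 68.1%
Compound 3: `CNC(=O)c1cc(Oc2ccc3nc(NC(=O)c4cccc(F)n4)sc3c2)ccn1` — 10.8%

In a functional assay on HCT-116 cells (Homo sapiens) for inhibition, read by MTT assay, with a stated time of 2 days, tested at 10 uM (on this read-out lower numbers stand for less inhibition of growth and higher numbers for more inhibition of growth at the one concentration tested), compound 1 sits second of three: compound 3 gives 10.8%, a lower number, while compound 2 gives 68.1%, far higher. Compound 4 `CNC(=O)c1cc(Oc2ccc3nc(NC(=O)Nc4ccc(Br)cc4)sc3c2)ccn1` differs from compound 1 by bromo in place of 4-methylpiperazin-1-yl on an aromatic carbon. Going by the values given here, no measured pair tries this swap. Among the compounds with values here, the only step at the same position, a number 43.5 percentage points higher from compound 1 to compound 2 (beyond the scatter), was large, so this place matters, but it tells nothing about a bromine there. Compound 4 is therefore expected to move only modestly, with the direction unsure, by a number 10.4 percentage points higher from compound 1 to compound 4 (beyond the scatter), and its estimated value is 35%, within a range from 10% to 65%.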

Compound 4, percent growth inhibition at one concentration: 12.1%
Compound 4: middle estimate off by 22.9 percentage points, on the high side; the measured number falls inside the stated range.
By their numbers in this assay, from the lowest: compounds 3 and 4 (each within the scatter of the next); then compound 1; then compound 2.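

In this assay, a lone bromo on this aromatic carbon gives up much of the inhibition: a number 12.5 percentage points lower from compound 1 to compound 4 (beyond the scatter), and a number 56 percentage points lower from compound 2 to compound 4 (beyond the scatter), so both larger ring-bearing groups outperform it. Placing (4-bromophenyl)amino instead of 6-fluoropyridin-2-yl on the carbonyl carbon gives a number 1.3 percentage points higher from compound 3 to compound 4 (within the scatter), so this assay does not separate those two compounds. Nothing available here explains these steps. From the compounds shown here alone, it remains open whether dimethylamino or a carboxylic acid at this aromatic carbon would restore inhibition, and whether piperidin-4-yl without its isopropyl group would match compound 2.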